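Replacing the chloro group of compound 3

This account rests on a few compounds, and the source may have more. Where it says the series, first, only, none or still open, it means among the compounds named here.

Of the compounds shown here, three with a shared core have been measured so far in a physicochemical assay for solubility, read by nephelometry, measured as kinetic solubility, at pH 2.0 (on this read-out higher numbers stand for higher solubility and lower numbers for lower solubility), on one scale. Compound 1 `CCOC(=O)C1=C(C)N/C(=C/c2cc(C)n(-c3cccc(C(F)(F)F)c3)c2C)C1=O` gives 1 ug/mL and compound 2 `CCOC(=O)C1=C(C)N/C(=C/c2cc(C)n(-c3ccc(F)cc3F)c2C)C1=O` gives 3.1 ug/mL while compound 3 `CCOC(=O)C1=C(C)N/C(=C/c2cc(C)n(-c3ccc(Cl)cc3)c2C)C1=O` gives 1.6 ug/mL in the same test. Compound 3 thus sits within the scatter of both others, with a 1.6-fold higher number from compound 1 to compound 3 (0.20 log units; within the scatter) and a 1.9-fold lower number from compound 2 to compound 3 (0.29 log units; within the scatter) as its steps. Compound 4 `CCOC(=O)C1=C(C)N/C(=C/c2cc(C)n(-c3ccc(SC(F)(F)F)cc3)c2C)C1=O` carries (trifluoromethyl)sulfanyl in place of chloro on an aromatic carbon as its change, (trifluoromethyl)sulfanyl in place of chloro on an aromatic carbon. Among the measured compounds shown here, no measured step makes this exact swap, but changes of the group on the aromatic nitrogen stayed small, the largest being a 3.1-fold higher number from compound 1 to compound 2 (0.49 log units; beyond the scatter) in this series. So no step beyond the scatter is expected in this assay here. The expected step is a 1.3-fold lower number from compound 3 to compound 4 (0.12 log units; within the scatter) on this estimate. Compound 4 is estimated at 1.2 ug/mL with an expected range from 0.6 ug/mL to 2.5 ug/mL for repeat measurements.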

Compound 4, solubility: 1 ug/mL
Compound 4: middle estimate off by 1.2-fold (0.08 log units), on the high side; the measured number falls inside the stated range.
By their numbers in this assay, from the lowest: compounds 1, 4, 3 and 2 (each within the scatter of the next, the first and the last beyond it).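

This is the first change shown on a carbon of the outer six-membered aromatic ring with the group on the aromatic nitrogen otherwise kept, para to a large group. In this assay, going from chloro, 1 heavy atom, to (trifluoromethyl)sulfanyl, 5 heavy atoms, gives a 1.6-fold lower number from compound 3 to compound 4 (0.20 log units; within the scatter), so this larger group leaves no difference that can be told from repeat scatter. No measured property is available to explain this result. Going by these compounds, what an amine or a carboxylic acid at this place would do to the number stays open.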